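Hydroxymethyl series: methoxy for fluoro on the fused ring

The source may report more compounds than this note shows. Statements on the series, on what has been measured and on what is new or still open speak of the compounds shown alone.

Measured so far:
compound 1 `O=Cc1cn(Cc2ccc(Cl)cc2)c2ccc(F)cc12`, in a functional assay on T29Kt1 cells (Homo sapiens) for cytotoxicity, read by sulforhodamine B assay, with a stated time of 3 days (a lower number here means a stronger inhibitor, a higher number a weaker inhibitor), compound 1 gives 9090 nM
compound 2 `OCc1cn(Cc2ccc(Cl)cc2)c2ccc(F)cc12`, in this assay compound 2 gives 80 nM

Among the measured compounds shown here, compound 2 stands lowest of the two numbers, well apart from compound 1; the only measured step, a 110-fold lower number from compound 1 to compound 2 (2.06 log units; beyond the scatter), concerns the exchange of the formyl group for hydroxymethyl. Compound 3 `COc1ccc2c(c1)c(CO)cn2Cc1ccc(Cl)cc1` differs from compound 2 by methoxy in place of fluoro on an aromatic carbon. For the measured compounds named here, no measured step touches this exchange, so the one step available gives no guide to its size or direction. With nothing to suggest otherwise, the expected step is one within the scatter, a 1.5-fold higher number from compound 2 to compound 3 (0.18 log units; within the scatter). For compound 3 the estimate in this assay is 120 nM, with a range from 30 nM to 500 nM.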

Compound 3, half-maximal inhibitory concentration: 12500 nM
Compound 3: the middle estimate sits 100-fold (2.02 log units) below what was measured, outside the stated range (above it).
By their numbers in this assay, from the lowest: compound 2; then compounds 1 and 3 (each within the scatter of the next).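

The fluoro position on the fused ring strongly affects the read-out in the hydroxymethyl series: in this assay, methoxy in place of fluoro gives a 160-fold higher number from compound 2 to compound 3 (2.19 log units; beyond the scatter). Hydroxymethyl alone therefore does not secure a low number, since compound 3 keeps that group and still reads high. Nothing available accounts for the size of this step.

Going by these compounds, it remains open how chloro, methyl or hydroxyl on this carbon would read. Whether any group other than fluoro here can keep the number low also remains unsettled.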